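The compounds below may be only part of what the source reports. "The series", "measured", "known", "first", "only" and "open" are said of these compounds alone.

Compound 1 `CCC1CCCN(C(=O)CN2CN(c3ccccc3)C3(CCN(C(=O)c4ccc(C(C)(C)C)cc4)CC3)C2=O)C1` was tested in an assay on HEK293 cells for displacement of a labelled ligand from NPC1-like intracellular cholesterol transporter 1 (Homo sapiens) (a higher number here means a weaker inhibitor, a lower number a stronger inhibitor), where compound 1 gives 3900 nM. Going by the values given here, of the three compounds measured so far this is the second highest number, though all three lie within the scatter of one another. Compound 2 `CC(C)(C)OC(=O)NC1CCCN(C(=O)CN2CN(c3ccccc3)C3(CCN(C(=O)c4ccc(C(C)(C)C)cc4)CC3)C2=O)C1` gives 4200 nM, and compound 3 `CCC1CCCN(C(=O)CN2CN(c3ccccc3)C3(CCN(C(=O)c4ccc(C5CCCCC5)cc4)CC3)C2=O)C1` gives 2600 nM. The step of a 1.1-fold higher number from compound 1 to compound 2 (0.03 log units; within the scatter) alters a saturated ring carbon inside the very 3-ethylpiperidin-1-yl group that compound 4 replaces, while a 1.5-fold lower number from compound 1 to compound 3 (0.18 log units; within the scatter) touches an aromatic carbon elsewhere. Compound 4 `CC(C)(C)c1ccc(C(=O)N2CCC3(CC2)C(=O)N(CC(=O)NCCCCNS(C)(=O)=O)CN3c2ccccc2)cc1` differs from compound 1 by (4-(methanesulfonamido)butyl)amino in place of 3-ethylpiperidin-1-yl on a carbonyl carbon. Among the compounds with values here, because a 1.1-fold higher number from compound 1 to compound 2 (0.03 log units; within the scatter) stayed within the scatter, and no measured step covers so complete a swap, compound 4 is expected to give about 5000 nM, within 1500 nM to 16000 nM, a step of a 1.3-fold higher number from compound 1 to compound 4 (0.11 log units; within the scatter).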

Compound 4, half-maximal inhibitory concentration: 4500 nM
For compound 4 the middle estimate is 1.1-fold (0.05 log units) above the measured one; measured number inside the range.
By their numbers in this assay, from the lowest: compounds 3, 1, 2 and 4 (each within the scatter of the next).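

In this assay the open chain (4-(methanesulfonamido)butyl)amino can stand on this carbonyl carbon in place of the ring of 3-ethylpiperidin-1-yl, with a 1.2-fold higher number from compound 1 to compound 4 (0.06 log units; within the scatter) and so no real change. Going by these compounds alone, the earlier step altered only one carbon of that ring, whereas this one removes the ring and adds 2 hydrogen-bond donors, so the ring is not needed to keep this level of binding. No evidence explains this result. As far as these compounds go, it remains open whether a shorter chain, or a terminal amine or carboxylic acid in place of the methanesulfonamide, would move the number beyond the scatter.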